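The source may hold more compounds than are shown below. What is called first, only, known or untested is meant among the compounds shown, and "the series" means these compounds.

Compound 3 `CC1CC/C(=N\Nc2ccccc2I)c2ncc(C(=O)O)c(=O)n21` is the starting point here. In a functional assay on the whole organism for inhibition, with Rattus norvegicus as the target (on this read-out higher numbers stand for an effect only at larger amounts of compound and lower numbers for an effect already at smaller amounts), compound 3 gives > 1000 umol/kg, which is a limit of the assay rather than a measured number, the point marked by the limit of > 1000 umol/kg in this assay, at which 1 of the 3 values shown sits. Two close relatives share its core. Compound 1 `CC1CC/C(=N\Nc2cccc(Cl)c2)c2ncc(C(=O)O)c(=O)n21` carries a 3-chlorophenyl on the amine nitrogen where compound 3 carries a 2-iodophenyl. In this assay compound 1 gives > 100 umol/kg, also only a limit, as the limit of > 100 umol/kg in this assay, at which 1 of the 3 values shown sits, records. Compound 2 `CC1CC/C(=N\Nc2cccc(Br)c2)c2ncc(C(=O)O)c(=O)n21` carries a 3-bromophenyl in that place. In this assay compound 2 gives > 320 umol/kg, again a limit, as the limit of > 320 umol/kg in this assay, at which 1 of the 3 values shown sits, records. With every value sitting at a limit, the steps a step that the two limits leave unreadable from compound 1 to compound 2, a step that the two limits leave unreadable from compound 1 to compound 3 and a step that the two limits leave unreadable from compound 2 to compound 3 have no readable size. Compound 4 `CC1CC/C(=N\Nc2ccccc2O)c2ncc(C(=O)O)c(=O)n21` differs from compound 3 by hydroxy in place of iodo on an aromatic carbon. For the measured compounds named here, no measured step bears on this change, and nothing in the three values points to an effect at smaller amounts. Compound 4 is therefore expected at 1000 umol/kg, within 300 umol/kg to 3000 umol/kg. The expected step is a number no higher from compound 3 to compound 4 (the limit leaves the size open), most likely reported again as a limit.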

Compound 4, dose for 50% inhibition: > 100 umol/kg
Compound 4 ended at the assay's limit; the forecaster's own chance of this, stated with the estimate: 70%; the middle value is on the limit's open side.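

Compound 4 gives only a limit in this assay, as do compound 1, compound 2 and compound 3, and none of the steps among these four compounds can be read. The compounds shown leave open whether hydroxy in place of iodo changes the dose needed at all.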